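Swapping cyano for methyl at the assay limit

This account rests on a few compounds, and the source may have more. Where it says the series, first, only, none or still open, it means among the compounds named here.

Measured in a functional assay on B16-F0 cells (Mus musculus) for inhibition, read by CCK-8 assay, with a stated time of 48 h; a higher number here means a weaker inhibitor, a lower number a stronger inhibitor:
Compound 1 `COc1cc(-c2cc3nccc(-c4cc(OC)c(OC)c(OC)c4)n3n2)cc(OC)c1OC`: > 10000 nM (a limit)
Compound 2 `COc1cc(-c2ccnc3cc(-c4cn(CO)c5ccccc45)nn23)cc(OC)c1OC`: 93 nM
Compound 3 `COc1cc(-c2ccnc3cc(-c4cccc(C#N)c4)nn23)cc(OC)c1OC`: > 10000 nM (a limit)

Compound 3 stands at the limit of > 10000 nM in this assay, at which 2 of the 3 values shown sit. Its entry is therefore a limit and not a number. Compound 2 is the only one of the three with a true number, 93 nM.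

Compound 4 `COc1cc(-c2ccnc3cc(-c4cccc(C)c4)nn23)cc(OC)c1OC` keeps the shared core of compound 3 and changes one group, with methyl in place of cyano on an aromatic carbon. In other words, 3-cyanophenyl becomes 3-methylphenyl. Among the measured compounds shown here, no measured pair of compounds shows what this swap does in this assay, so any forecast is loose. The expectation rests on compound 3 at > 10000 nM, a limit, and on the swap touching a single group. A small change is expected, if any, towards a stronger inhibitor: an at least 1.2-fold lower number from compound 3 to compound 4 (0.09 log units; that floor lies within the scatter). For compound 4 the estimated value is 8000 nM, with an expected range from 1000 nM to 20000 nM.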

Compound 4, half-maximal inhibitory concentration: 2220 nM
Compound 4: the middle estimate sits 3.6-fold (0.56 log units) above what was measured, and the stated range covers the measured number.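

In this assay, replacing cyano with methyl on this aromatic carbon gives an at least 4.5-fold lower number from compound 3 to compound 4 (0.65 log units; beyond the scatter), the first measured step of any kind among the compounds shown. Compound 4 gives 2220 nM, a true number, so a 3-substituted phenyl on the shared core can show measurable inhibition in this test, something compound 3 left unknown. The step can be stated only as a minimum because compound 3 has a limit and not a number: the limit of > 10000 nM in this assay, at which 2 of the 4 values shown sit.

Only cyano and methyl are shown at this place, so a single pair cannot show a trend across groups. From the compounds shown here alone, whether a methoxy group, a chlorine atom or an amine at the same carbon would give a lower or a higher number remains open.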